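The compounds below may be only part of what the source reports. "The series", "measured", "known", "first", "only" and "open" are said of these compounds alone.

Measured in a functional assay on GC3/MTK- cells (Homo sapiens) for inhibition; a higher number here means a weaker inhibitor, a lower number a stronger inhibitor:
- compound 1 `C#CCN(Cc1ccc2nc(C)nc(O)c2c1)c1cccc(Br)c1`: 5300 nM
- compound 2 `C#CCN(Cc1ccc2nc(C)nc(O)c2c1)c1cccc(I)c1`: > 5300 nM (a limit, not a number)
- compound 3 `C#CCN(Cc1ccc2nc(C)nc(O)c2c1)c1ccc(C#N)cc1`: 5000 nM

Compound 3 stands level with compound 1, as a 1.1-fold lower number from compound 1 to compound 3 (0.03 log units; within the scatter) shows. Compound 2 gives only a limit, so an at least 1.0-fold lower number from compound 2 to compound 3 (0.02 log units; that floor lies within the scatter) and a number no lower from compound 1 to compound 2 (the limit leaves the size open) fix no real size. Compound 4 `C#CCN(Cc1ccc2nc(C)nc(O)c2c1)c1ccc(C#N)c(Cl)c1` differs from compound 3 by one change: chloro in place of hydrogen on an aromatic carbon. Going by the values given here, no measured step adds a chloro, so the data give no direction. Still, compound 1 and compound 3 differ in their whole aryl group, and a 1.1-fold lower number from compound 1 to compound 3 (0.03 log units; within the scatter) stays within the scatter, so no large step is expected. The expected step is a 1.1-fold lower number from compound 3 to compound 4 (0.05 log units; within the scatter), which is none beyond the scatter. For compound 4 the estimated value in this assay is 4500 nM, within an expected range of 1800 nM to 11000 nM.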

Compound 4, half-maximal inhibitory concentration: 6700 nM
Beside the measured number, compound 4's estimate is 1.5-fold (0.17 log units) below it; low and high end bracket the measured number.
By their numbers in this assay, from the lowest: compounds 3, 1 and 4 (each within the scatter of the next).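

In this assay, chloro in place of hydrogen, ortho to a cyano group, gives a 1.3-fold higher number from compound 3 to compound 4 (0.13 log units; within the scatter). Among the compounds shown, this is the only step that adds a chloro. It shows that this position takes the added atom with no change beyond the scatter, so the chloro brings neither a clear gain nor a clear loss here.

Going by these compounds, whether an amine or a carboxylic acid at this position would move the number beyond the scatter stays open. Compound 2 gives only a limit, so the steps that involve it cannot be read: the limit of > 5300 nM in this assay, at which 1 of the 4 values shown sits.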